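Methyl in Place of Methoxy: What to Expect for Compound 3

A few compounds are considered here, and "the series" means these few. Any claim that something is new, unique, unknown or untested is made for them only; others in the source may bear on it.

Of the compounds shown here, two sharing one core have been measured in a functional assay on B16-F10 cells (Mus musculus) for inhibition, read by MTT assay, with a stated time of 72 h; on this read-out higher numbers stand for weaker inhibition and lower numbers for stronger inhibition. Compound 1 `CC(C)c1ccc(-c2nc(SCc3cn(CC(=O)NC(=O)Nc4ccccn4)nn3)nc(Nc3cccc(C(F)(F)F)c3)c2C#N)cc1` gives 1700 nM. Compound 2 `COc1ccc(Nc2nc(SCc3cn(CC(=O)NC(=O)Nc4ccccn4)nn3)nc(-c3ccc(C(C)C)cc3)c2C#N)cc1` gives 360 nM, the lower of the two numbers. For the measured compounds named here, the single measured step, a 4.7-fold lower number from compound 1 to compound 2 (0.67 log units; beyond the scatter), comes from 4-methoxyphenyl in place of 3-(trifluoromethyl)phenyl on a nitrogen on an aromatic ring.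

Compound 3 `Cc1ccc(Nc2nc(SCc3cn(CC(=O)NC(=O)Nc4ccccn4)nn3)nc(-c3ccc(C(C)C)cc3)c2C#N)cc1` differs from compound 2 in one place: methyl in place of methoxy on an aromatic carbon, a methyl in place of methoxy on an aromatic carbon of a six-membered aromatic ring of carbon only, para to a large group. Going by the values given here, no measured step exchanges methoxy for methyl, so the step from compound 1 to compound 2 bears on it only in showing that the group on that nitrogen can shift the read-out in this assay by a modest amount. A change this small is expected to stay near the scatter.

For compound 3 a step of a 1.3-fold higher number from compound 2 to compound 3 (0.10 log units; within the scatter) is therefore expected in this assay, and the estimate is 450 nM, in the range 150 nM to 1400 nM.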

Compound 3, half-maximal inhibitory concentration: 3060 nM
Compound 3: the middle estimate sits 6.8-fold (0.83 log units) below what was measured, outside the stated range (above it).
By their numbers in this assay, from the lowest: compound 2; then compounds 1 and 3 (each within the scatter of the next).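

In this assay, methyl in place of methoxy on this aromatic carbon is not a minor exchange: the result is an 8.5-fold higher number from compound 2 to compound 3 (0.93 log units; beyond the scatter), so this position responds strongly to a change that removes only one oxygen and one hydrogen-bond acceptor. The earlier step could not separate the effect of the para substituent from that of the whole aryl group, but the new comparison gives a 1.8-fold higher number from compound 1 to compound 3 (0.26 log units; within the scatter), and 4-methylphenyl and 3-(trifluoromethyl)phenyl on that nitrogen cannot be told apart in this read-out. Among these three compounds, only the one bearing 4-methoxyphenyl stands apart, with both of its steps beyond the scatter, and nothing available accounts for this difference.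

The compounds shown leave open whether the oxygen is what matters, which a hydroxy, ethoxy or dimethylamino group on the same aromatic carbon would help to test. They also leave open whether a group such as fluorine or chlorine at this place would read like methyl or like methoxy.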